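The compounds below may be only part of what the source reports. "The series", "measured", "known", "first", "only" and "open" are said of these compounds alone.

Compound 1 `O=C(Nc1ncc(Cc2ccc(F)cc2)s1)c1ccccc1` — "not toxic" (no number reported)
Compound 2 `O=C(Nc1ncc(Cc2ccc(F)cc2)s1)c1ccc(Cl)cc1Cl` — > 50000 nM
Compound 3 `Clc1ccc(C(Oc2ccc3cc(Br)ccc3c2)c2cnc(NCC3CCOCC3)s2)cc1` — "not toxic" (no number reported)

The three measured compounds were all run in an ADME assay on HepG2 2.2.15 cells (Homo sapiens) for cytotoxicity (a higher number here means that more compound is tolerated, a lower number that less compound is tolerated), and none gave a single number. Compound 1 is recorded only as "not toxic" (no number reported). Compound 2 is recorded as > 50000 nM, which is a limit of the assay and not a number. Compound 3, the starting point of this step, is likewise recorded only as "not toxic" (no number reported). Among the three entries one further value is a limit and one further entry has no number, so compound 3 stands nowhere on a scale, only alongside entries that tolerated the top of the tested range, the one numerical entry sitting at the limit of > 50000 nM in this assay, at which 1 of the 3 values shown sits.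

From compound 3 the change to compound 4 `COc1ccc(C(=O)Nc2ncc(C(Oc3ccc4cc(Br)ccc4c3)c3ccc(Cl)cc3)s2)cc1` is (4-methoxyphenyl)carbonyl in place of (oxan-4-yl)methyl on a nitrogen on an aromatic ring

Among the compounds with values here, no measured pair differs in one place, so no step size can be read from the data. With every measured entry at or beyond the tested range in this assay, the writer expects compound 4 to show no change beyond the scatter, in either direction. Compound 4 is therefore expected to give about 50000 nM in this assay, with a range from 20000 nM to 100000 nM.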

Compound 4, half-maximal cytotoxic concentration: > 50000 nM
Compound 4 was reported as a limit (the forecaster's own chance of this, stated with the estimate: 75%); the middle value lies on the limit itself.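

No step can be read from compound 3 to compound 4 in this assay, as compound 3 has no single number. Compound 4 gives > 50000 nM, which is a limit of the assay. The compounds shown leave open at what concentration any of them would harm these cells, and whether exchanging (oxan-4-yl)methyl for (4-methoxyphenyl)carbonyl changes that concentration: the limit of > 50000 nM in this assay, at which 2 of the 4 values shown sit.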